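A few compounds are considered here, and "the series" means these few. Any claim that something is new, unique, unknown or untested is made for them only; others in the source may bear on it.

Compounds measured in a functional assay on COLO 205 cells (Homo sapiens) for inhibition, read by sulforhodamine B assay; on this read-out higher numbers stand for weaker inhibition of growth and lower numbers for stronger inhibition of growth
Compound 1 `COc1ccc(-c2ccc(-c3ccc(-c4nc5cc(C)ccc5[nH]4)cc3)cc2)cc1OC` gives 2320 nM
Compound 2 `COc1ccc(-c2ccc(-c3ccc(-c4nc5ccccc5[nH]4)cc3)cc2)cc1OC` gives 41200 nM
Compound 3 `COc1ccc(-c2ccc(-c3ccc(-c4nc5c(O)cccc5[nH]4)cc3)cc2)cc1OC` gives 1320 nM

Among these three numbers, compound 1 cannot be told apart from its nearest neighbour (a 1.8-fold lower number from compound 1 to compound 3 (0.24 log units; within the scatter)). Its furthest neighbour lies well away (an 18-fold higher number from compound 1 to compound 2 (1.25 log units; beyond the scatter)).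

The next compound to be tested is compound 4 `Cc1ccc2[nH]c(-c3ccc(-c4ccc(-c5ccc(C(F)(F)F)cc5)cc4)cc3)nc2c1`, which carries 4-(trifluoromethyl)phenyl in place of 3,4-dimethoxyphenyl on an aromatic carbon. None of the three measured steps touches this group, since all of them keep the 3,4-dimethoxyphenyl and differ elsewhere. They therefore give no direct guide to the size or direction of this change. They do show that one small substitution elsewhere can move the number a long way (a 31-fold lower number from compound 2 to compound 3 (1.49 log units; beyond the scatter)), so the range has to stay wide.

For the measured compounds named here, with no measured step to point either way, no step beyond the scatter is expected in this assay, and the estimate stays close to the value of compound 1 (2320 nM). The expected step is small (a 1.3-fold higher number from compound 1 to compound 4 (0.11 log units; within the scatter)). For compound 4 the estimated value is 3000 nM (expected range 400 nM to 20000 nM).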

Compound 4, concentration for 50% growth inhibition: 30600 nM
Compound 4: middle estimate off by 10-fold (1.01 log units), on the low side; measured number outside the range, above it.
By their numbers in this assay, from the lowest: compounds 3 and 1 (each within the scatter of the next); then compounds 4 and 2 (each within the scatter of the next).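

In this assay, changing the 3,4-dimethoxyphenyl group proves far from silent: 4-(trifluoromethyl)phenyl in its place, on an aromatic carbon para to a large group, gives a 13-fold higher number from compound 1 to compound 4 (1.12 log units; beyond the scatter), which means weaker inhibition of growth. For the compounds shown here, the earlier compounds all kept the 3,4-dimethoxyphenyl group and differed elsewhere, so this is the first sign that this end of the molecule also matters, and that a step beyond the scatter can arise here as well as at the place changed in an 18-fold higher number from compound 1 to compound 2 (1.25 log units; beyond the scatter). The two groups have the same count of 10 heavy atoms, while the entering group has 0 hydrogen-bond acceptors and the leaving group has 2, but no measurement here explains the step.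

The compounds shown leave open whether the step follows the loss of the two methoxy groups or the arrival of the trifluoromethyl group; a plain phenyl or a 4-methoxyphenyl at this place would separate the two. Going by these compounds alone, they also leave open whether the same exchange has a similar effect on compound 2 or compound 3, for it is seen only on compound 1.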